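The compounds below may be only part of what the source reports. "The series", "measured", "known", "first", "only" and "open" are said of these compounds alone.

Measured so far in a physicochemical assay for lipophilicity, read by spectrophotometry, measured as octanol-water partition, at pH 7.4; on this read-out lower numbers stand for lower lipophilicity and higher numbers for higher lipophilicity:
- compound 1 `CCOc1cc(CN2CCC(NC(=O)c3cncc(C)c3)CC2)cc(OCC)c1-c1ccc(F)cc1` gives 4.01
- compound 2 `CCOc1cc(CN2CCC(NC(=O)c3cncc(C)c3)CC2)cc(OCC)c1Cl` gives 3.43

Of these two numbers, the lower belongs to compound 2, at 3.43, while compound 1 stands higher at 4.01.

Next comes compound 3 `CCOc1cc(CN2CCC(NC(=O)c3cncc(C)c3)CC2)cc(OCC)c1F`, which keeps the shared core of compound 2 and differs in one place: fluoro in place of chloro on an aromatic carbon. This is fluoro in place of chloro, on an aromatic carbon ortho to two ethoxy groups and para to a large group.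

Going by the values given here, only one measured step bears on this change: a number 0.58 log units lower from compound 1 to compound 2 (beyond the scatter). It concerns the same carbon but a different exchange, chloro in place of 4-fluorophenyl, so it gives no direct size for the present one. Resting on that step and on the exchange of chloro for fluoro, a smaller move in the same direction is expected in this assay. Among the compounds with values here, the expected step is a number 0.38 log units lower from compound 2 to compound 3 (beyond the scatter), and this estimate has only that one indirect step behind it. Compound 3 is estimated at 3.05, with an expected range from 2.75 to 3.35.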

Compound 3, distribution coefficient: 2.9
Compound 3: middle estimate off by 0.15 log units, on the high side; low and high end bracket the measured number.
By their numbers in this assay, from the lowest: compound 3; then compound 2; then compound 1.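

In this assay, this aromatic carbon, ortho to two ethoxy groups and para to a large group, now has three substituents that can be compared directly, and the read-out still responds when one single heavy atom replaces another with no ring involved: a number 0.53 log units lower from compound 2 to compound 3 (beyond the scatter) stands beyond the scatter. The earlier compounds shown here showed a change at this carbon only through the loss of the 4-fluorophenyl ring, whereas the halogen exchange shows that the choice between chloro and fluoro also matters here. Across the three compounds, the widest change at this carbon is a number 1.11 log units lower from compound 1 to compound 3 (beyond the scatter) and the order runs from 4-fluorophenyl through chloro to fluoro, with no compound in the set going against it. Nothing at hand gives a reason for the size of either step.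

Open, as far as these compounds go, is where hydrogen, a methoxy group, an amine or a carboxylic acid on this carbon would fall relative to these three substituents. Also open, from the compounds shown here alone, is whether the fluoro-for-chloro step keeps its size when a longer chain replaces the two ethoxy groups.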